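A few compounds are considered here, and "the series" means these few. Any claim that something is new, unique, unknown or untested is made for them only; others in the source may bear on it.

Measured compounds:
Compound 1 `COc1ccc(-c2cn3ccnc3c(-c3ccc4ncn(C5CCCCC5)c4c3)n2)cc1`: 68.9%
Compound 2 `Fc1ccc(-c2cn3ccnc3c(-c3ccc4ncn(C5CCCCC5)c4c3)n2)cc1`: 20.3%
Compound 3 `CC(=O)c1ccc(-c2cn3ccnc3c(-c3ccc4ncn(C5CCCCC5)c4c3)n2)cc1`: 4.68%

The three compounds share one core and differ only in the group on an aromatic carbon of the outer phenyl ring. In a functional assay on BT-549 cells (Homo sapiens) for inhibition, read by sulforhodamine B assay, with a stated time of 48 h, tested at 10 uM (on this read-out lower numbers stand for less inhibition and higher numbers for more inhibition at the one concentration tested (going by the name of the read-out)), compound 3 gives 4.68%, the lowest of the three numbers; compound 2 is nearest, and compound 1 furthest, both beyond the scatter.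

Compound 4 `Clc1ccc(-c2cn3ccnc3c(-c3ccc4ncn(C5CCCCC5)c4c3)n2)cc1` has not been measured. It differs from compound 3 in one place: chloro in place of acetyl on an aromatic carbon. Going by the values given here, no measured step involves chloro, so the nearest guide is the step in which acetyl replaced fluoro on that aromatic carbon, a number 15.6 percentage points lower from compound 2 to compound 3 (beyond the scatter), a modest fall. Read in reverse, removing acetyl in favour of a small group gave a modest gain. The larger steps of a number 48.6 percentage points lower from compound 1 to compound 2 (beyond the scatter) and a number 64.2 percentage points lower from compound 1 to compound 3 (beyond the scatter) show that methoxy stands well apart from both fluoro and acetyl, but say nothing directly about chloro. A modest rise is therefore expected for compound 4, about a number 15.3 percentage points higher from compound 3 to compound 4 (beyond the scatter), with an estimated value of 20% and a range from 3% to 45%.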

Compound 4, a percentage reported as inhibition, at one concentration (the size of the read-out at that concentration, not a potency): 23.8%
The estimate for compound 4 lay 3.8 percentage points below the measured number; the range from low to high includes it.
By their numbers in this assay, from the lowest: compound 3; then compounds 2 and 4 (each within the scatter of the next); then compound 1.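

In this assay, chloro in place of acetyl on this aromatic carbon gives a number 19.1 percentage points higher from compound 3 to compound 4 (beyond the scatter), so the low number of compound 3 is not shared by every replacement at this position. The two halogens cannot be told apart here, with a number 3.5 percentage points higher from compound 2 to compound 4 (within the scatter), which a single fluoro compound could not show. Chloro also falls well short of methoxy, with a number 45.1 percentage points lower from compound 1 to compound 4 (beyond the scatter), so among the four groups shown, methoxy alone gives a high number.

The compounds shown leave open how an amine, a carboxylic acid or a longer ether such as ethoxy would read on this same carbon, and so whether the high number belongs to methoxy alone. Nothing available explains why these groups differ in this way.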